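Removing the propargyl group from compound 2

This account rests on a few compounds, and the source may have more. Where it says the series, first, only, none or still open, it means among the compounds named here.

Values in a functional assay (muscle tissue) with Rattus norvegicus as the target; a lower number here means that less compound is needed, a higher number that more compound is needed for the effect:
- Compound 1 `CC(C)NC(=O)C1=CC(C)(C)Oc2ccc([N+](=O)[O-])cc21`: 186 nM
- Compound 2 `C#CCNC(=O)C1=CC(C)(C)Oc2ccc([N+](=O)[O-])cc21`: 7.94 nM
- Compound 3 `CC1(C)C=C(C(N)=O)c2cc([N+](=O)[O-])ccc2O1`: not yet measured

Of the two measured compounds, compound 2 has the lower number in this assay, at 7.94 nM, and needs clearly less compound than compound 1. Moving on to compound 3 puts hydrogen in place of propargyl on an amide-type nitrogen.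

Going by the values given here, only one measured step bears on this change, and it sits on the same nitrogen: a 23-fold lower number from compound 1 to compound 2 (1.37 log units; beyond the scatter). That large step shows that the group here can move the number strongly. Among the compounds with values here, no compound with hydrogen at this place has been measured, so the size remains uncertain. A clear rise is expected, of roughly similar size, beyond the scatter.

The expected change is an 11-fold higher number from compound 2 to compound 3 (1.05 log units; beyond the scatter). The estimate for compound 3 is 90 nM, with an expected range from 15 nM to 500 nM.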

Compound 3, half-maximal effective concentration: 363 nM
Beside the measured number, compound 3's estimate is 4.0-fold (0.61 log units) below it; measured number inside the range.
By their numbers in this assay, from the lowest: compound 2; then compounds 1 and 3 (each within the scatter of the next).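

In this assay, taking the propargyl group off the amide-type nitrogen gives a 46-fold higher number from compound 2 to compound 3 (1.66 log units; beyond the scatter), so the low number of compound 2 is lost when hydrogen replaces propargyl. Isopropyl and hydrogen, by contrast, cannot be told apart at this place, with a 2.0-fold higher number from compound 1 to compound 3 (0.29 log units; within the scatter), so among these three compounds only propargyl sets its compound apart, and simply having a carbon group on this nitrogen is not enough. Nothing measured here explains why propargyl differs from the other two groups.

Going by these compounds, it remains open whether the triple bond matters or the three-carbon chain alone would do, which a plain propyl chain on the same nitrogen could show. A longer chain ending in a triple bond, such as butynyl, would show whether the chain length can change.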